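From Chloro to Dimethylamino: An Untested Swap

The source may report more compounds than this note shows. Statements on the series, on what has been measured and on what is new or still open speak of the compounds shown alone.

Among the measured compounds shown here, in a functional assay on the whole organism (strain Kunming) with Mus musculus as the target, in the maximal electroshock model (on this read-out lower numbers stand for an effect already at smaller amounts and higher numbers for an effect only at larger amounts of compound), compound 1 `O=C(/C=C/c1ccc(Cl)cc1)NCCO` gives 73.4 mg/kg and holds the higher of the two numbers so far. Compound 2 `O=C(/C=C/c1ccccc1F)NCCO` gives 35.3 mg/kg and lies lower by a gap beyond the usual scatter. Compound 3 `CN(C)c1ccc(/C=C/C(=O)NCCO)cc1` is still unmeasured. It has dimethylamino in place of chloro on an aromatic carbon of compound 1 (dimethylamino in place of chloro on an aromatic carbon). For the measured compounds named here, no measured pair shows this kind of swap, so the direction remains open. The estimated step of a 1.1-fold higher number from compound 1 to compound 3 (0.04 log units; within the scatter) is expected to stay within the scatter. For compound 3 the expected dose is 80 mg/kg with an estimated range from 35 mg/kg to 190 mg/kg as its upper end.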

Compound 3, dose for half-maximal effect: 66.1 mg/kg
The estimate for compound 3 lay 1.2-fold (0.08 log units) above the measured number; measured number inside the range.
By their numbers in this assay, from the lowest: compounds 2, 3 and 1 (each within the scatter of the next, the first and the last beyond it).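

In this assay, the swap of chloro for dimethylamino on the aromatic carbon para to a group of 8 heavy atoms gives a 1.1-fold lower number from compound 1 to compound 3 (0.05 log units; within the scatter). Among the compounds shown here, this is the first single-place comparison, and it shows that the larger group, with 3 heavy atoms in place of 1, leaves the dose within the scatter. No data on hand say why the two groups read alike.

From the compounds shown here alone, whether a carboxylic acid or a morpholine ring on this carbon would also leave the dose within the scatter remains open.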